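Acetyl in place of isobutyl: compound 2 to compound 3

The source may report more compounds than this note shows. Statements on the series, on what has been measured and on what is new or still open speak of the compounds shown alone.

- compound 1 `C=C1[C@H](OCC(C)C)C[C@@H](OC(=O)c2cccnc2)C(C)(C)/C=C/[C@@H](C)C(=O)[C@@]2(OC(C)=O)C[C@H](C)[C@H](OC(C)=O)[C@@H]2[C@H]1OC(C)=O`: 5.9%
- compound 2 `C=C1[C@H](OCC(C)C)C[C@@H](OC(=O)c2cccnc2)C(C)(C)/C=C/[C@@H](C)C(=O)[C@@]2(OC(C)=O)C[C@@](C)(OC(C)=O)[C@H](OC(C)=O)[C@@H]2[C@H]1OC(C)=O`: 17.5%

For the measured compounds named here, only two measurements exist so far, both in a functional assay on Ishikawa cells (Homo sapiens) for inhibition, read by MTT assay, with a stated time of 72 h, tested at 10 ug/mL; a lower number here means less inhibition of growth, a higher number more inhibition of growth at the concentration tested. Compound 2 holds the higher number at 17.5%, and compound 1 lies at 5.9%, a gap beyond the usual scatter. These two compounds differ in more than one place, so their gap says nothing about the next change.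

The next compound to be tested is compound 3 `C=C1[C@H](OC(C)=O)C[C@@H](OC(=O)c2cccnc2)C(C)(C)/C=C/[C@@H](C)C(=O)[C@@]2(OC(C)=O)C[C@@](C)(OC(C)=O)[C@H](OC(C)=O)[C@@H]2[C@H]1OC(C)=O`, which keeps everything in compound 2 except one group: acetyl in place of isobutyl on an oxygen on a saturated carbon. In words, this puts acetyl in place of isobutyl on an oxygen on a saturated carbon, or isobutoxy to acetoxy. Going by the values given here, no measured pair shows this change, so its effect has no direct precedent. Compound 2, at 17.5%, is the closest reference, and no step beyond the scatter is expected in this assay, with at most a slight lean downward. The estimate amounts to an expected a number 3.5 percentage points lower from compound 2 to compound 3 (within the scatter). For compound 3 the estimated value is 14%, with an expected range of 3% to 28%.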

Compound 3, percent growth inhibition at one concentration: 8.1%
Compound 3: middle estimate off by 5.9 percentage points, on the high side; measured number inside the range.
By their numbers in this assay, from the lowest: compounds 1, 3 and 2 (each within the scatter of the next, the first and the last beyond it).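

In this assay, the series now holds one step that can be read at a single place: acetyl in place of isobutyl on an oxygen on a saturated carbon gives a number 9.4 percentage points lower from compound 2 to compound 3 (within the scatter) and so stays inside the usual spread of repeats. At this oxygen, then, isobutoxy and acetoxy cannot be told apart by this read-out at the concentration tested, and the isobutyl group is not shown to be needed for the growth inhibition seen with compound 2. This one pair gives no rule for the series, and nothing available explains the step.

Open, on these data alone, is whether another group on this oxygen, such as a free hydroxyl, a benzoyl ester or an aminoalkyl chain, would move the number beyond the scatter in this assay. Also open, as far as these compounds go, is whether the same exchange would read the same way on the core of compound 1, and whether a full concentration series would separate compound 2 and compound 3 where a single concentration does not.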